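Adding One Carbon to a Growing Side Chain

The source may hold more compounds than are shown below. What is called first, only, known or untested is meant among the compounds shown, and "the series" means these compounds.

Compound 1, `Cc1ccc(NC(=O)N[C@@H](C)c2ccccc2)cc1`, gives 99% in an ADME assay on the whole organism with Oryza sativa as the target, tested at 1 uM; on this read-out higher numbers stand for a weaker effect at the one concentration tested and lower numbers for a stronger effect.
Compound 2, `CCc1ccc(NC(=O)N[C@@H](C)c2ccccc2)cc1`, gives 95% in this assay.
Compound 3, `CCCCCc1ccc(NC(=O)N[C@@H](C)c2ccccc2)cc1`, gives 98% in this assay.

All three numbers sit close together, and compound 3 cannot be told apart from the others: a number 1 percentage points lower from compound 1 to compound 3 (within the scatter) and a number 3 percentage points higher from compound 2 to compound 3 (within the scatter). Compound 4, `CCCCCCc1ccc(NC(=O)N[C@@H](C)c2ccccc2)cc1`, carries the change (methyl in place of hydrogen on a saturated chain carbon, five bonds along the chain from an aromatic carbon). The steps already seen are all of the same kind, a chain on the shared core growing longer, and each stayed flat: a number 4 percentage points lower from compound 1 to compound 2 (within the scatter), a number 1 percentage points lower from compound 1 to compound 3 (within the scatter), a number 3 percentage points higher from compound 2 to compound 3 (within the scatter). Nothing here points to a step beyond the scatter in this assay in either direction. Compound 4 is therefore expected to give 97% in this assay, between 90% and 100%. The expected step is a number 1 percentage points lower from compound 3 to compound 4 (within the scatter).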

Compound 4, a percentage reported as activity, at one concentration (the size of the read-out at that concentration, not a potency): 100%
Compound 4: the middle estimate sits 3 percentage points below what was measured; the range from low to high includes it.
By their numbers in this assay, from the lowest: compounds 2, 3, 1 and 4 (each within the scatter of the next).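

Adding a methyl at this place, five bonds along the chain from an aromatic carbon, gives no readable change in this assay: there is a number 2 percentage points higher from compound 3 to compound 4 (within the scatter). Compound 4 also stays level with the shorter chains, with a number 5 percentage points higher from compound 2 to compound 4 (within the scatter) and a number 1 percentage points higher from compound 1 to compound 4 (within the scatter), so among these four compounds, chain length up to this one separates nothing. The same change also reads alike on two cores: the same change on two cores in this assay, a number 4 percentage points lower (within the scatter) from compound 1 to compound 2 and a number 2 percentage points higher (within the scatter) from compound 3 to compound 4, 6 percentage points apart, within the scatter of two such steps.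

Still open, as far as these compounds go, is whether an amine or a carboxylic acid at the chain end, or a much longer chain, would give a step beyond the scatter.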